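Removing a Bromo Group from a Weakly Cytotoxic Oxadiazoline

This account rests on a few compounds, and the source may have more. Where it says the series, first, only, none or still open, it means among the compounds named here.

Measured compounds:
- Compound 2, `CC(=O)N1N=C(c2ccc(-n3c(C)ccc3C)cc2)OC1c1ccc(Br)cc1`: 195000 nM
- Compound 3, `O=C(NNC(=O)c1ccccc1Br)c1ccc(-n2cccc2)cc1`: 201000 nM
- Compound 1, `Cc1ccc(C)n1-c1ccc(C(=O)N/N=C/c2ccc(Br)cc2)cc1`: "not determined" (no result reported)

In an ADME assay on A549 cells (Homo sapiens) for cytotoxicity, read by MTT assay, with a stated time of 72 h (on this read-out lower numbers stand for stronger inhibition and higher numbers for weaker inhibition), compound 2 gives 195000 nM. In this assay compound 3 gives 201000 nM. Compound 2 holds the lowest of the two numbers, but its gap to compound 3 lies within the scatter, so neither can be called stronger than the other. In this assay compound 1 gives "not determined" (no result reported). All numbers in hand are high, which on this read-out means weak inhibition.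

The step under consideration leads from compound 2 to compound 4, `CC(=O)N1N=C(c2ccc(-n3c(C)ccc3C)cc2)OC1c1ccccc1`. The change is hydrogen in place of bromo on an aromatic carbon; cut one bond further out, it reads as 4-bromophenyl to phenyl. Within the data shown here, no measured pair here shows what such a change does, so there is no step to lean on. With only weakly active compounds available, the step is expected to be small, with a 1.0-fold higher number from compound 2 to compound 4 (0.01 log units; within the scatter) within the scatter. Compound 4 is therefore expected to give about 200000 nM, with a range of 100000 nM to 400000 nM.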

Compound 4, half-maximal inhibitory concentration: 198000 nM
Compound 4: middle estimate off by 1.0-fold (0.00 log units), on the high side; measured number inside the range.
By their numbers in this assay, from the lowest: compounds 2, 4 and 3 (each within the scatter of the next).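

In this assay, among these compounds, putting hydrogen in place of bromo on the aromatic carbon gives a 1.0-fold higher number from compound 2 to compound 4 (0.01 log units; within the scatter), which is the first measured pair to test this position. Going from 4-bromophenyl to phenyl therefore makes no difference that this read-out can detect, and the bromo is not needed for the weak inhibition seen with compound 2. No supporting data are available to explain this result.

Only bromo and hydrogen are shown on this carbon, so it remains open whether a different group, such as an amine or a carboxylic acid, would shift the number beyond the scatter. Going by these compounds, it also remains open whether the same exchange would have so little effect on a compound with a much lower number in this assay.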